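This account rests on a few compounds, and the source may have more. Where it says the series, first, only, none or still open, it means among the compounds named here.

In a functional assay on the whole organism with Mus musculus as the target (on this read-out lower numbers stand for an effect already at smaller amounts and higher numbers for an effect only at larger amounts of compound), compound 1 `O=c1oc2cc(Br)cnc2n1CCN1CCN(c2ccccc2)CC1` gives 34.1 mg/kg. Compound 2 `COc1ccccc1N1CCN(CCn2c(=O)oc3cccnc32)CC1` reaches only a limit of the assay, > 50 mg/kg, so for compound 2 no number is known, and it sits at the limit of > 50 mg/kg in this assay, at which 1 of the 2 values shown sits. Compound 3 `O=c1oc2cccnc2n1CCN1CCN(c2ccccc2)CC1` differs from compound 2 by hydrogen in place of methoxy on an aromatic carbon. Among the measured compounds shown here, no measured step covers this change, so its size and direction are open. Compound 3 is expected to give 45 mg/kg in this assay, with a range from 20 mg/kg to 100 mg/kg. The expected step is an at least 1.1-fold lower number from compound 2 to compound 3 (0.04 log units; that floor lies within the scatter), which may not exceed the scatter.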

Compound 3, dose for half-maximal effect: 19.4 mg/kg
Compound 3: the middle estimate sits 2.3-fold (0.37 log units) above what was measured; measured number outside the range, below it.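

In this assay, going from 2-methoxyphenyl to phenyl gives an at least 2.5-fold lower number from compound 2 to compound 3 (0.41 log units; beyond the scatter), the first sign that the methoxy at this place on the aromatic ring costs more than the scatter. Compound 2 stands only at a limit, so this step has a floor but no full size: the limit of > 50 mg/kg in this assay, at which 1 of the 3 values shown sits. Hydrogen in place of bromo on the core gives a 1.8-fold lower number from compound 1 to compound 3 (0.24 log units; within the scatter), so this read-out does not separate the two. The compounds shown leave open how a smaller group, such as fluoro or hydroxyl, would read at the methoxy's place on the ring. They also leave open whether an amine on the core would read differently from hydrogen or bromo.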